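A Single Fluoro on the Benzyl Group

The source may hold more compounds than are shown below. What is called first, only, known or untested is meant among the compounds shown, and "the series" means these compounds.

Going by the values given here, in a functional assay on NCI/ADR-RES cells (Homo sapiens) for antiproliferative activity, read by MTT assay, with a stated time of 48 h (on this read-out higher numbers stand for weaker inhibition and lower numbers for stronger inhibition), compound 1 (`Cc1c(Cc2ccccc2)c(=O)oc2cc(OCCOc3no[n+]([O-])c3S(=O)(=O)c3ccccc3)ccc12`) gives 16.3 nM as the lower of the two numbers measured so far. Compound 2 (`COc1cc(OCCOc2no[n+]([O-])c2S(=O)(=O)c2ccccc2)ccc1C(=O)/C=C/c1ccc(F)cc1`) gives 47.9 nM as the higher number, a gap beyond the usual scatter, which leaves compound 1 the stronger inhibitor of the pair.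

Compound 3 (`Cc1c(Cc2ccc(F)cc2)c(=O)oc2cc(OCCOc3no[n+]([O-])c3S(=O)(=O)c3ccccc3)ccc12`) has not been measured yet. It differs from compound 1 in one place (fluoro in place of hydrogen on an aromatic carbon), which turns benzyl into 4-fluorobenzyl. Among the compounds with values here, no measured pair shows this change on its own. In this assay the estimated step of a 1.0-fold lower number from compound 1 to compound 3 (0.01 log units; within the scatter) is expected to stay within the usual scatter, with no clear direction. For compound 3 the estimated value is 16 nM with an expected range from 6.5 nM to 40 nM in this measurement.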

Compound 3, half-maximal inhibitory concentration: 5.1 nM
Estimate against measurement, compound 3: 3.1-fold (0.50 log units) above; measured number outside the range, below it.
By their numbers in this assay, from the lowest: compound 3; then compound 1; then compound 2.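

In this assay the change from benzyl to 4-fluorobenzyl gives a 3.2-fold lower number from compound 1 to compound 3 (0.50 log units; beyond the scatter) and so lies beyond the scatter, though the step is modest. Going by these compounds alone, this shows that the position on the benzyl ring, para to a large group, responds to the addition of a single fluorine atom, and that the response here is towards stronger inhibition, which the earlier compounds could not show because they offered no pair with this change alone. Nothing available explains why the number moved.

Whether this gain is special to fluoro remains open, since the compounds shown say nothing about chloro, methoxy or trifluoromethyl at the same place. It is also unclear whether an amine or a carboxylic acid there would be tolerated, or whether fluoro elsewhere on the ring would do the same.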